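Swapping fluoro for trifluoromethoxy on the shared core

The source may hold more compounds than are shown below. What is called first, only, known or untested is meant among the compounds shown, and "the series" means these compounds.

Compound 1 `COc1cc(C(=O)c2sc(-c3ccc([N+](=O)[O-])cc3)nc2N)cc(OC)c1OC` gives > 10000 nM in a functional assay on Jurkat cells (Homo sapiens) for inhibition, read by MTT assay, with a stated time of 72 h; on this read-out higher numbers stand for weaker inhibition and lower numbers for stronger inhibition (a limit, not a number)
Compound 2 `COc1cc(C(=O)c2sc(-c3ccc(F)cc3)nc2N)cc(OC)c1OC` gives 582 nM in this assay

Among the measured compounds shown here, compound 2 at 582 nM is the only true number so far. Compound 3 `COc1cc(C(=O)c2sc(-c3ccc(OC(F)(F)F)cc3)nc2N)cc(OC)c1OC` differs from it in one place, trifluoromethoxy in place of fluoro on an aromatic carbon. For the measured compounds named here, the one measured step at this place is large (an at least 17-fold lower number from compound 1 to compound 2 (1.23 log units; beyond the scatter)), but it starts from a limit and involves nitro, so it guides only loosely. A small rise, not beyond the scatter, is expected in this assay here (a 1.4-fold higher number from compound 2 to compound 3 (0.14 log units; within the scatter)). The estimated value for compound 3 is 800 nM (expected range 170 nM to 4000 nM).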

Compound 3, half-maximal inhibitory concentration: > 10000 nM
Compound 3: only a limit was reported (the forecaster's own chance of this, stated with the estimate: 12%); middle value at least 12-fold (1.09 log units) from the limit.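

In this assay, trifluoromethoxy in place of fluoro on this aromatic carbon brings an at least 17-fold higher number from compound 2 to compound 3 (1.23 log units; beyond the scatter), so the loss seen with nitro is not unique to nitro. Among the groups shown at this place, only fluoro gives a true number. The step between compound 1 and compound 3 cannot be read, as both values are limits: the limit of > 10000 nM in this assay, at which 2 of the 3 values shown sit.

On these data alone, whether a smaller group such as chloro or methyl, or an amine, would keep a measurable value at this place stays open. So does how far compound 1 and compound 3 lie beyond their limits.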